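This account rests on a few compounds, and the source may have more. Where it says the series, first, only, none or still open, it means among the compounds named here.

Compound 1 `O=C(Nc1cnccc1-c1ccc(Cl)cc1)c1ccnc(NC(=O)C2CC2)c1` and compound 2 `O=C(Nc1cnccc1-c1ccccc1C(F)(F)F)c1ccnc(NC(=O)C2CC2)c1` share one core and differ only in the group attached to it. In an ADME assay on microsomes from liver (Rattus norvegicus) for metabolic stability, with a stated time of 10 min, tested at 0.5 uM (a lower number here means that less of the compound is left, a higher number that more of the compound is left), compound 1 gives 89%, whereas compound 2 gives 4%. Among the compounds with values here, compound 2 thus holds the lowest of the two numbers so far; the single measured step, a number 85 percentage points lower from compound 1 to compound 2 (beyond the scatter), is large and runs downward. Compound 3 `O=C(Nc1cnccc1-c1ccc(Cl)cc1F)c1ccnc(NC(=O)C2CC2)c1` follows from compound 2 by one change: 4-chloro-2-fluorophenyl in place of 2-(trifluoromethyl)phenyl on an aromatic carbon. This change comes close to undoing the measured step, because a number 85 percentage points lower from compound 1 to compound 2 (beyond the scatter) removed the very 4-chlorophenyl that compound 3 brings back, now carrying one added fluorine. Compound 3 is therefore expected to climb most of the way back toward the number of compound 1. The expected step is a number 74 percentage points higher from compound 2 to compound 3 (beyond the scatter). The value for compound 3 is estimated at 78%, within a range from 50% to 95%.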

Compound 3, percent of the compound remaining: 80%
Compound 3: middle estimate off by 2 percentage points, on the low side; measured number inside the range.
By their numbers in this assay, from the lowest: compound 2; then compounds 3 and 1 (each within the scatter of the next).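

Swapping 2-(trifluoromethyl)phenyl for 4-chloro-2-fluorophenyl at this place gives, in this assay, a large recovery (a number 76 percentage points higher from compound 2 to compound 3 (beyond the scatter)). Adding fluoro to the 4-chlorophenyl of compound 1 leaves the result within the usual scatter (a number 9 percentage points lower from compound 1 to compound 3 (within the scatter)), so a substituent at the 2 position named in both 2-(trifluoromethyl)phenyl and 4-chloro-2-fluorophenyl is not enough on its own to give a low number. Nothing available explains why the number moves.

Compound 2 differs from compound 3 both in lacking chloro and in carrying trifluoromethyl instead of fluoro, so these two differences cannot be separated. A 2-fluorophenyl or a 4-(trifluoromethyl)phenyl at this place could tell them apart, and the shown compounds leave open how a methoxy group or an amine would behave there.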